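Bromo for Chloro: A Small Halogen Swap Weighed

This account rests on a few compounds, and the source may have more. Where it says the series, first, only, none or still open, it means among the compounds named here.

Compound 1, `FC(F)(F)c1ccc(CSc2nc(N3CCCCC3)c3ccccc3n2)cc1`: in a functional assay on HGC-27 cells (Homo sapiens) for cytotoxicity, read by MTT assay, with a stated time of 72 h (a lower number here means a stronger inhibitor, a higher number a weaker inhibitor), compound 1 reaches only a limit of the assay, > 50000 nM.
Compound 2, `Cc1ccccc1Nc1nc(SCc2ccc(C(F)(F)F)cc2)nc2ccccc12`: compound 2 gives 27500 nM.
Compound 3, `FC(F)(F)c1ccc(CSc2nc(Nc3cccc(Cl)c3)c3ccccc3n2)cc1`: compound 3 gives 19900 nM.

Of the two plain numbers, compound 3 holds the lower one, but the gap to compound 2, a 1.4-fold lower number from compound 2 to compound 3 (0.14 log units; within the scatter), sits within the scatter, so no order between them can be claimed. Compound 1 stands at a limit (the limit of > 50000 nM in this assay, at which 1 of the 3 values shown sits), and the step of an at least 2.5-fold lower number from compound 1 to compound 3 (0.40 log units; beyond the scatter) is the only one beyond the scatter; the step of an at least 1.8-fold lower number from compound 1 to compound 2 (0.25 log units; that floor lies within the scatter) has a floor within it.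

Compound 4, `FC(F)(F)c1ccc(CSc2nc(Nc3cccc(Br)c3)c3ccccc3n2)cc1`, differs from compound 3 by bromo in place of chloro on an aromatic carbon. Within the data shown here, no measured step trades one halogen for another; the closest comparison is the change of the whole ring on the nitrogen, a 1.4-fold lower number from compound 2 to compound 3 (0.14 log units; within the scatter), which stayed within the scatter. A change smaller than that is expected to give no step beyond the scatter in this assay, so for compound 4 the expected step is a 1.1-fold lower number from compound 3 to compound 4 (0.04 log units; within the scatter). Compound 4 is therefore estimated at 18000 nM, between 8000 nM and 45000 nM.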

Compound 4, half-maximal inhibitory concentration: 18300 nM
Estimate against measurement, compound 4: 1.0-fold (0.01 log units) below; low and high end bracket the measured number.
By their numbers in this assay, from the lowest: compounds 4, 3 and 2 (each within the scatter of the next). At a limit, above all of these: compound 1.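

Among these compounds, this is the first direct trade of one halogen for another, on an aromatic carbon meta to a large group, and in this assay the step of a 1.1-fold lower number from compound 3 to compound 4 (0.04 log units; within the scatter) shows that chloro and bromo cannot be told apart here. Set against the 2-methylphenyl group of compound 2, the step of a 1.5-fold lower number from compound 2 to compound 4 (0.18 log units; within the scatter) also stays within the scatter, so compound 2, compound 3 and compound 4 cannot be put in any order. Replacing piperidin-1-yl with (3-bromophenyl)amino gives an at least 2.7-fold lower number from compound 1 to compound 4 (0.43 log units; beyond the scatter) as a second step beyond the scatter, but that size is only a floor, since compound 1 stands at a limit of the assay: the limit of > 50000 nM in this assay, at which 1 of the 4 values shown sits.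

From the compounds shown here alone, whether an amine or a carboxylic acid in place of the halogen would move the number beyond the scatter stays open. So does whether fluoro or iodo would read the same as chloro and bromo.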